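The source may report more compounds than this note shows. Statements on the series, on what has been measured and on what is new or still open speak of the compounds shown alone.

In an ADME assay on Vero cells (Chlorocebus sabaeus) for cytotoxicity (a higher number here means that more compound is tolerated, a lower number that less compound is tolerated), compound 1 `CCN(CC)CC(=O)Nc1ccc(-c2nc3cc(C(F)(F)F)ccc3n2C)cc1` gives 90000 nM. Compound 2 `Cn1c(-c2ccc(NC(=O)CN3CCCCC3)cc2)nc2cc(C(F)(F)F)ccc21` reaches only the limit of the assay, > 100000 nM. Compound 3 `O=C(CN1CCCC1)Nc1ccc(-c2nc3cc(C(F)(F)F)ccc3[nH]2)cc1` likewise sits at the limit, > 100000 nM, so for compound 3 no number is known, only a floor; see (the limit of > 100000 nM in this assay, at which 2 of the 3 values shown sit).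

The step to compound 4 `Oc1ccc(-c2nc3cc(C(F)(F)F)ccc3[nH]2)cc1` is
hydroxy in place of (((pyrrolidin-1-yl)methyl)carbonyl)amino on an aromatic carbon
For the measured compounds named here, the one measured step, an at least 1.1-fold higher number from compound 1 to compound 2 (0.04 log units; that floor lies within the scatter), exchanged one amine for another and stayed within the scatter. It bears only loosely on the present change, which removes the whole amine-bearing amide rather than varying it. With nothing showing movement in this assay, no step beyond the scatter is expected here.

Compound 4 is therefore estimated at 100000 nM, within 40000 nM to 250000 nM. The expected a number no higher from compound 3 to compound 4 (the limit leaves the size open) is thus no change beyond the scatter.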

Compound 4, half-maximal cytotoxic concentration: > 100000 nM
Compound 4: only a limit was reported; the forecaster's own chance of this, stated with the estimate: 50%; the middle value sits exactly at the limit.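

In this assay compound 3 at > 100000 nM is only a limit. For the compounds shown here, compound 4 at > 100000 nM is also only a limit, so no step between compound 3 and compound 4 can be read. As far as these compounds go, whether hydroxy in that place changes the tolerated concentration at all stays open.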